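The source may hold more compounds than are shown below. What is called first, only, known or untested is meant among the compounds shown, and "the series" means these compounds.

In an assay (Rattus norvegicus) for inhibition of Fatty-acid amide hydrolase 1 (Homo sapiens) (on this read-out lower numbers stand for stronger inhibition and higher numbers for weaker inhibition), compound 2 `NC(=O)c1cccc(-c2cnc(C(=O)CCCCCCc3ccccc3)o2)n1` gives 1 nM, the lowest of the two numbers measured, while compound 1 `O=C(CCCCCCc1ccccc1)c1ncc(-c2ccc(O)cc2)o1` gives 140 nM. For the measured compounds named here, the one measured step between them, a 140-fold lower number from compound 1 to compound 2 (2.15 log units; beyond the scatter), came from a single exchange on an aromatic carbon of the shared core. Compound 3 `O=C(CCCCCCc1ccccc1)c1ncc(-c2ccncn2)o1` is altered at that same place: pyrimidin-4-yl in place of 6-carbamoylpyridin-2-yl on an aromatic carbon. Because the carbamoylpyridinyl group brought a 140-fold lower number from compound 1 to compound 2 (2.15 log units; beyond the scatter), its departure is expected to raise the number again, though the step back need not be the full size. The expected step is a 30-fold higher number from compound 2 to compound 3 (1.48 log units; beyond the scatter). Compound 3 is therefore estimated at 30 nM, with a range from 5 nM to 200 nM.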

Compound 3, inhibition constant: 2.3 nM
Beside the measured number, compound 3's estimate is 13-fold (1.12 log units) above it, outside the stated range (below it).
By their numbers in this assay, from the lowest: compound 2; then compound 3; then compound 1.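

At this position the low numbers do not depend on the 6-carbamoylpyridin-2-yl group: replacing it with the smaller pyrimidin-4-yl, which has 0 hydrogen-bond donors, costs only a 2.3-fold higher number from compound 2 to compound 3 (0.36 log units; beyond the scatter). Most of the gain over 4-hydroxyphenyl survives the change, with a 61-fold lower number from compound 1 to compound 3 (1.78 log units; beyond the scatter). Nothing available explains why these two nitrogen-containing rings differ so much from 4-hydroxyphenyl. Still open, as far as these compounds go, is whether a plain phenyl ring, an unsubstituted pyridin-2-yl, or a pyridin-2-yl bearing a carboxylic acid would keep the number as low.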